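A few compounds are considered here, and "the series" means these few. Any claim that something is new, unique, unknown or untested is made for them only; others in the source may bear on it.

Going by the values given here, compound 2 `O=C(NCCCO)c1cc2ccccc2oc1=O` is one of three compounds measured in an assay on HEK293 cells for displacement of a labelled ligand from adenosine receptor A2b (Homo sapiens), read by scintillation counting, with a stated time of 30 min, tested at 10 uM (a lower number here means less inhibition, a higher number more inhibition at the concentration tested (going by the name of the read-out)), where compound 2 gives 19%. Compound 1 `O=C(NC1CCCC1)c1cc2ccccc2oc1=O` gives 18% in this assay, and the step of a number 1 percentage points higher from compound 1 to compound 2 (within the scatter) shows that the two sit together. Compound 3 `COc1cccc2cc(C(=O)NC3CCCCC3)c(=N)oc12` reaches only a limit of this assay, > 70%. That value is the limit of > 70% in this assay, at which 1 of the 3 values shown sits. Compound 4 `O=C(NCCCO)c1cc2cccc(O)c2oc1=O` differs from compound 2 by hydroxy in place of hydrogen on an aromatic carbon. Among the compounds with values here, no measured step touches the aromatic ring in this way; the only measured step, a number 1 percentage points higher from compound 1 to compound 2 (within the scatter), concerns the amide-type nitrogen and stays within the scatter. For compound 4 the expected step is therefore a number 1 percentage points higher from compound 2 to compound 4 (within the scatter), nothing beyond the scatter. The estimate for compound 4 is 20%, with a range from 8% to 35%.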

Compound 4, a percentage reported as inhibition, at one concentration (the size of the read-out at that concentration, not a potency): 24%
Compound 4: the middle estimate sits 4 percentage points below what was measured; low and high end bracket the measured number.
By their numbers in this assay, from the lowest: compounds 1, 2 and 4 (each within the scatter of the next). At a limit, above all of these: compound 3.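

Measured in this assay the change gives a number 5 percentage points higher from compound 2 to compound 4 (within the scatter) for hydroxy in place of hydrogen on an aromatic carbon, ortho to a fused ring. Going by these compounds alone, this is the first look at a change on this aromatic ring, and compound 2 and compound 4 sit together, so here a hydroxy group on this carbon leaves the read-out within the scatter. Nothing shown gives a reason for this result.

Open, as far as these compounds go, is whether a methoxy group or an amine on this carbon would also stay within the scatter. Also open, from the compounds shown here alone, is whether hydroxy on this carbon would do the same alongside the cyclopentyl group of compound 1.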